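Phenyl on the Ring Nitrogen: An Expected Shift

This account rests on a few compounds, and the source may have more. Where it says the series, first, only, none or still open, it means among the compounds named here.

Compound 1 `COc1ccc([N+](=O)[O-])cc1CSc1nc2cc(NC(=O)NC(C)(C)C)ccc2n1C1CC1` in an assay on isolated protein for inhibition of Gonadotropin-releasing hormone receptor (Homo sapiens) (on this read-out lower numbers stand for stronger inhibition and higher numbers for weaker inhibition), gives 79 nM.
Compound 2 `CCCCCn1c(SCc2cc([N+](=O)[O-])ccc2OC)nc2cc(NC(=O)NC(C)(C)C)ccc21` in this assay gives 210 nM.
Compound 3 `COCCn1c(SCc2cc([N+](=O)[O-])ccc2OC)nc2cc(NC(=O)NC(C)(C)C)ccc21` in this assay gives 57 nM.

Compound 3 has the lowest number of the three, yet its gap to compound 1 is within the scatter, so these two cannot be ranked against each other; only compound 2 stands clearly apart, as the step of a 3.7-fold lower number from compound 2 to compound 3 (0.57 log units; beyond the scatter) shows. Compound 4 `COc1ccc([N+](=O)[O-])cc1CSc1nc2cc(NC(=O)NC(C)(C)C)ccc2n1-c1ccccc1` differs from compound 3 in one place: phenyl in place of 2-methoxyethyl on an aromatic nitrogen. The measured steps that bear on this change all alter the group on the same nitrogen: a 1.4-fold lower number from compound 1 to compound 3 (0.14 log units; within the scatter), a 2.7-fold higher number from compound 1 to compound 2 (0.42 log units; beyond the scatter) and a 3.7-fold lower number from compound 2 to compound 3 (0.57 log units; beyond the scatter). They show that swapping this group moves the number modestly at most, but none of them places a phenyl there, so the direction for compound 4 cannot be read off directly. Compound 4 is therefore expected to land close to the measured compounds, with a step of a 1.9-fold higher number from compound 3 to compound 4 (0.29 log units; within the scatter) estimated as modest. The estimate for compound 4 in this assay is 110 nM, with a range from 35 nM to 350 nM.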

Compound 4, half-maximal inhibitory concentration: 350 nM
Estimate against measurement, compound 4: 3.2-fold (0.50 log units) below; the measured number falls inside the stated range.
By their numbers in this assay, from the lowest: compounds 3 and 1 (each within the scatter of the next); then compounds 2 and 4 (each within the scatter of the next).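

In this assay, for the compounds shown here, this nitrogen responds more to phenyl than the earlier compounds suggested: the change gives a 6.1-fold higher number from compound 3 to compound 4 (0.79 log units; beyond the scatter) and a 4.4-fold higher number from compound 1 to compound 4 (0.65 log units; beyond the scatter), both beyond the scatter and the two largest steps at this position among the four compounds. Against the pentyl group, phenyl gives a 1.7-fold higher number from compound 2 to compound 4 (0.22 log units; within the scatter), which is within the scatter, so compound 2 and compound 4 cannot be ranked and the four compounds fall into two pairs, with cyclopropyl and 2-methoxyethyl in one and pentyl and phenyl in the other. Nothing shown here explains why the groups divide in this way.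

As far as these compounds go, it remains open whether a ring on this nitrogen could do better if it were attached through a carbon, as in benzyl. A 2-hydroxyethyl or 2-aminoethyl chain would also show whether the oxygen of 2-methoxyethyl matters, or whether a shorter chain such as ethyl serves equally well.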